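A few compounds are considered here, and "the series" means these few. Any claim that something is new, unique, unknown or untested is made for them only; others in the source may bear on it.

Working notes on the series. Among the measured compounds shown here, in an ADME assay on MT4 cells (Homo sapiens) for cytotoxicity, read by MTT assay (a lower number here means that less compound is tolerated, a higher number that more compound is tolerated), compound 1 (`Cc1ccccc1C(=O)N(C(=S)OCCN1C(=O)c2ccccc2C1=O)c1ccc(Cl)cc1`) gives 21000 nM, the lower of the two true numbers so far. Compound 2 (`O=C1c2ccccc2C(=O)N1CCOC(=S)N(C(=O)c1ccc(Br)cc1)c1ccc(Br)cc1`) gives 73000 nM, a higher number than compound 1. Compound 3 (`Cc1ccc(N(C(=O)c2ccccc2C)C(=S)OCCN2C(=O)c3ccccc3C2=O)cc1`) gives > 100000 nM, which is a limit of the assay and not a number.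

The next comparison is compound 4 (`O=C1c2ccccc2C(=O)N1CCOC(=S)N(C(=O)c1ccc(F)cc1F)c1ccc(Cl)cc1`), which carries 2,4-difluorophenyl in place of 2-methylphenyl on a carbonyl carbon. The core of compound 1 and its other substituents stay unchanged.

For the measured compounds named here, the only measured step, an at least 4.7-fold higher number from compound 1 to compound 3 (0.67 log units; beyond the scatter), is methyl in place of chloro on an aromatic carbon. It lies elsewhere in the molecule, so it bears on this change only indirectly, showing that a single substitution can move the number in this assay beyond the scatter. Going by the values given here, no measured step changes the group on the carbonyl carbon, so the expectation is weak: at most a modest move towards a higher number, and possibly none beyond the scatter. The expected step is a 1.7-fold higher number from compound 1 to compound 4 (0.22 log units; within the scatter), and this rests on compound 1 at 21000 nM as the starting point. For compound 4 the estimate is 35000 nM, with an expected range from 12000 nM to 95000 nM.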

Compound 4, half-maximal cytotoxic concentration: 52000 nM
Estimate against measurement, compound 4: 1.5-fold (0.17 log units) below; low and high end bracket the measured number.
By their numbers in this assay, from the lowest: compound 1; then compounds 4 and 2 (each within the scatter of the next). At a limit, above all of these: compound 3.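

In this assay, the group on the carbonyl carbon now has a measured step of its own: 2,4-difluorophenyl in place of 2-methylphenyl gives a 2.5-fold higher number from compound 1 to compound 4 (0.39 log units; beyond the scatter). Until now, the only measured step was at a different place in the molecule, the methyl in place of chloro on an aromatic carbon, so the number in this assay is now shown to respond beyond the scatter at two separate places on the scaffold of compound 1. The change at the carbonyl carbon is modest in size, and it is a single exchange of whole groups, so it removes a methyl and adds two fluorines at once without showing what each contributes.

As far as these compounds go, it remains open whether one fluorine alone, an unsubstituted phenyl, or a non-aromatic group such as a cyclohexyl ring or a longer alkyl chain on this carbonyl carbon would read the same way, and whether an amine or a carboxylic acid on the aryl ring would move the number in either direction. Any further upward move can be followed only as far as the ceiling of the assay: the limit of > 100000 nM in this assay, at which 1 of the 4 values shown sits.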